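Exchanging the Aryl Group on a Shared Core

This account rests on a few compounds, and the source may have more. Where it says the series, first, only, none or still open, it means among the compounds named here.

Compound 1 `c1ccc(COc2ccc(C3CC(c4ccc5c(c4)OCCO5)=NN3c3ccccc3)cc2)cc1`: 1130 nM
Compound 2 `COc1ccc(C2CC(c3ccc4c(c3)OCCO4)=NN2c2ccccc2)cc1OC`: 2160 nM

Of the compounds shown here, two have been tested in a functional assay on WM 266-4 cells (Homo sapiens) for antiproliferative activity, read by MTT assay, with a stated time of 24 h; a higher number here means a weaker inhibitor of growth, a lower number a stronger inhibitor of growth. Compound 2 gives 2160 nM, the larger of the two numbers shown, while compound 1 gives 1130 nM; the gap between them lies within the usual scatter, so the two cannot be told apart on these data. For the measured compounds named here, no pair of measured compounds differs in a single place, so no measured step guides the next change.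

Compound 3 `Cc1ccc(C2CC(c3ccc4c(c3)OCCO4)=NN2c2ccccc2)cc1` is the new compound. It differs from compound 2 in one place: 4-methylphenyl in place of 3,4-dimethoxyphenyl on a saturated ring carbon.

Going by the values given here, with no comparable step available, the expected change from compound 2 to compound 3 is a 1.2-fold lower number from compound 2 to compound 3 (0.08 log units; within the scatter), a move that is not expected to exceed the scatter in either direction. Compound 3 is therefore estimated at 1800 nM, with a likely range from 700 nM to 4500 nM.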

Compound 3, concentration for 50% growth inhibition: 2530 nM
For compound 3 the middle estimate is 1.4-fold (0.15 log units) below the measured one, and the stated range covers the measured number.
By their numbers in this assay, from the lowest: compounds 1, 2 and 3 (each within the scatter of the next, the first and the last beyond it).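

In this assay, the group on the saturated ring carbon can change from 3,4-dimethoxyphenyl to 4-methylphenyl, losing its oxygen atoms and hydrogen-bond acceptors, with only a 1.2-fold higher number from compound 2 to compound 3 (0.07 log units; within the scatter). Read another way, the new compound gives the first step beyond the scatter: methyl in place of benzyloxy on an aromatic carbon gives a 2.2-fold higher number from compound 1 to compound 3 (0.35 log units; beyond the scatter), a modest change showing that the larger benzyloxy-bearing group goes with a lower number than the methyl-bearing one at this position. Nothing available accounts for either step.

As far as these compounds go, three substituted aryl groups give only a narrow view of this position, so the effect of an amine or a carboxylic acid on that aromatic ring remains open. From the compounds shown here alone, whether a longer chain in place of benzyloxy would lower the number further also remains unknown.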